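One methoxy group fewer on the aromatic ring

A few compounds are considered here, and "the series" means these few. Any claim that something is new, unique, unknown or untested is made for them only; others in the source may bear on it.

Among the compounds with values here, in a functional assay on U-251 cells (Homo sapiens) for inhibition, read by sulforhodamine B assay, with a stated time of 48 h (a lower number here means a stronger inhibitor of growth, a higher number a weaker inhibitor of growth), compound 2 (`COc1ccc(/C=C/C2(C)C=CC(=O)O2)c(OC)c1`) reads 62800 nM and holds the higher of the two numbers so far. Compound 1 (`CC1(/C=C/c2ccccc2C(F)(F)F)C=CC(=O)O1`) reads 14100 nM on the lower side. The gap between these two compounds lies beyond the scatter. Compound 3 (`COc1ccccc1/C=C/C1(C)C=CC(=O)O1`) is reached from compound 2 by hydrogen in place of methoxy on an aromatic carbon. Within the data shown here, no measured step shows this change on its own. Among the measured compounds shown here, compound 1 carries no methoxy group and reads 14100 nM as the only guide, so a modest move toward a lower number is expected, near the edge of the scatter. The expected move is a 2.1-fold lower number from compound 2 to compound 3 (0.32 log units; beyond the scatter) as estimated here. For compound 3 the estimate in this assay is 30000 nM (expected range 14000 nM to 70000 nM).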

Compound 3, concentration for total growth inhibition: 41100 nM
For compound 3 the middle estimate is 1.4-fold (0.14 log units) below the measured one; low and high end bracket the measured number.
By their numbers in this assay, from the lowest: compound 1; then compounds 3 and 2 (each within the scatter of the next).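

In this assay, hydrogen in place of methoxy on this aromatic carbon, para to a group of 9 heavy atoms, gives a 1.5-fold lower number from compound 2 to compound 3 (0.18 log units; within the scatter) and so leaves no readable effect of the methoxy group at this position. Methoxy in place of trifluoromethyl on an aromatic carbon gives a 2.9-fold higher number from compound 1 to compound 3 (0.46 log units; beyond the scatter) and is the step that clears the scatter, so among these three compounds the readable difference lies with that exchange and not with the carbon just emptied. Nothing measured on these compounds accounts for either step.

On these data alone, whether an amine or a hydroxyl group on the emptied carbon would read apart from hydrogen and methoxy remains open. Also open, as far as these compounds go, is whether a chlorine atom in place of trifluoromethyl would hold the number of compound 1 at 14100 nM or lose it.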